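A few compounds are considered here, and "the series" means these few. Any claim that something is new, unique, unknown or untested is made for them only; others in the source may bear on it.

Compound 1 `C/C(=C\CC/C(C)=C/CC[C@@H]1[C@@]2(C)CCC(=O)C(C)(C)[C@H]2CC[C@@]1(C)O)CC/C=C(\C)C(=O)OCc1cn(-c2ccc(F)c(Cl)c2)nn1`: > 150000 nM (a limit)
Compound 2 `C#CCOC(=O)/C(C)=C/CC/C(C)=C/CC/C(C)=C/CC[C@@H]1[C@@]2(C)CCC(=O)C(C)(C)[C@H]2CC[C@@]1(C)O`: 45100 nM

Within the data shown here, in a functional assay on A549 cells (Homo sapiens) for antiproliferative activity, read by MTT assay, with a stated time of 48 h (on this read-out higher numbers stand for weaker inhibition and lower numbers for stronger inhibition), compound 2 gives 45100 nM, the only actual number so far. For compound 1, the value > 150000 nM is a limit. Compound 3 `C/C(=C\CC/C(C)=C/CC[C@@H]1[C@@]2(C)CCC(=O)C(C)(C)[C@H]2CC[C@@]1(C)O)CC/C=C(\C)C(=O)OCc1cn(-c2cccc(C)c2)nn1` departs from compound 2 as follows: 1-(3-methylphenyl)-1H-1,2,3-triazol-4-yl in place of ethynyl on a saturated chain carbon bound to an oxygen next to a carbonyl group. Compound 1, with its limit of > 150000 nM, is the ground for expecting weaker inhibition, though only a moderate change. The estimated step is a 1.8-fold higher number from compound 2 to compound 3 (0.25 log units; within the scatter). Compound 3 is expected at 80000 nM, with an estimated range of 25000 nM to 200000 nM.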

Compound 3, half-maximal inhibitory concentration: > 150000 nM
Compound 3: no number, only a limit (the forecaster's own chance of this, stated with the estimate: 40%); middle value at least 1.8-fold (0.27 log units) away from the limit.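

At the saturated chain carbon bound to an oxygen next to a carbonyl group, 1-(3-methylphenyl)-1H-1,2,3-triazol-4-yl in place of ethynyl gives an at least 3.3-fold higher number from compound 2 to compound 3 (0.52 log units; beyond the scatter) in this assay, so this change costs inhibition by more than the scatter. The effect of 3-methylphenyl in place of 3-chloro-4-fluorophenyl on the aromatic nitrogen cannot be read, because compound 1 and compound 3 both stand at a limit: the limit of > 150000 nM in this assay, at which 2 of the 3 values shown sit.

Going by these compounds, the true size of the loss stays open. So does whether a triazole carrying a plain methyl, or a phenyl carrying an amine, would give a readable number.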